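The source may hold more compounds than are shown below. What is called first, only, known or untested is meant among the compounds shown, and "the series" means these compounds.

Measured compounds in a functional assay on HeLa cells (Homo sapiens) for inhibition; on this read-out higher numbers stand for weaker inhibition and lower numbers for stronger inhibition:
- compound 1 `O=C(O)CSC(CC(=O)c1ccccc1)C(=O)O`: 15000 nM
- compound 2 `Cc1ccc(C(=O)CC(SCC(=O)O)C(=O)O)c(C)c1`: 3830 nM
- compound 3 `Cc1ccc(C(=O)CC(SCC(=O)O)C(=O)O)cc1`: 17300 nM

Compound 3 gives the highest number of the three. Against compound 1 it stands a 1.2-fold higher number from compound 1 to compound 3 (0.06 log units; within the scatter); against compound 2 it stands a 4.5-fold higher number from compound 2 to compound 3 (0.65 log units; beyond the scatter).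

Compound 4 `CCc1ccc(C(=O)CC(SCC(=O)O)C(=O)O)cc1` differs from compound 3 by methyl in place of hydrogen on a saturated chain carbon bound to an aromatic carbon. Going by the values given here, no measured step makes this exact change. The two known steps both concern a methyl on an aromatic carbon: the change from compound 1 to compound 3 was within the scatter, and the change from compound 2 to compound 3 was modest. Neither bears directly on lengthening a chain, so no step beyond the scatter is expected in this assay for compound 4. Compound 4 is estimated at 14000 nM, range 5000 nM to 40000 nM, which means an expected step of a 1.2-fold lower number from compound 3 to compound 4 (0.09 log units; within the scatter).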

Compound 4, half-maximal inhibitory concentration: 4790 nM
The estimate for compound 4 lay 2.9-fold (0.47 log units) above the measured number; the measured number lies below the stated range.
By their numbers in this assay, from the lowest: compounds 2 and 4 (each within the scatter of the next); then compounds 1 and 3 (each within the scatter of the next).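

In this assay the change from methyl to ethyl gives a step beyond the scatter (a 3.6-fold lower number from compound 3 to compound 4 (0.56 log units; beyond the scatter)), while methyl in place of hydrogen on an aromatic carbon stayed within the scatter (a 1.2-fold higher number from compound 1 to compound 3 (0.06 log units; within the scatter)). Replacing that hydrogen with ethyl also gives a step beyond the scatter (a 3.1-fold lower number from compound 1 to compound 4 (0.50 log units; beyond the scatter)), so at this place in the series the number moves with ethyl and not with methyl. Nothing available explains this step.

On these data alone, it remains open whether a propyl chain or a longer chain in the same place would lower the number further or reverse the step. A hydroxyl group or an amine on this chain is equally untested in the compounds shown.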